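Moving the hydroxyl on the hydrazone aryl ring

The compounds below may be only part of what the source reports. "The series", "measured", "known", "first", "only" and "open" are said of these compounds alone.

Measured compounds:
compound 1 `C#CCn1c(-c2ccc(C(=O)N/N=C/c3ccc[nH]3)cc2)nc2ccccc21` — in an assay on cells for inhibition of Amine oxidase [flavin-containing] B (Homo sapiens), read by fluorescence and Amplex Red, with stated times of 30 min and 5 min (a lower number here means a stronger inhibitor, a higher number a weaker inhibitor), compound 1 gives >= 1000000 nM, a limit of the assay.
compound 2 `C#CCn1c(-c2ccc(C(=O)N/N=C/c3ccc(O)cc3)cc2)nc2ccccc21` — in this assay compound 2 gives 1970 nM.
compound 3 `C#CCn1c(-c2ccc(C(=O)N/N=C/c3ccccc3OC)cc2)nc2ccccc21` — in this assay compound 3 gives >= 1000000 nM, a limit of the assay.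

Compound 2 holds the only number shown; the other two values sit at the limit of >= 1000000 nM in this assay, at which 2 of the 3 values shown sit. The change an at least 500-fold lower number from compound 1 to compound 2 (2.70 log units; beyond the scatter) is large, as is an at least 500-fold higher number from compound 2 to compound 3 (2.70 log units; beyond the scatter), while a step that the two limits leave unreadable from compound 1 to compound 3 cannot be read. Compound 4 `C#CCn1c(-c2ccc(C(=O)N/N=C/c3cccc(O)c3)cc2)nc2ccccc21` differs from compound 2 by 3-hydroxyphenyl in place of 4-hydroxyphenyl on a carbon with a double bond to nitrogen. Going by the values given here, no measured step moves a hydroxyl around the ring; all three exchange whole groups, so none bears directly on this change. A step of a 4.1-fold higher number from compound 2 to compound 4 (0.61 log units; beyond the scatter) is expected, most likely toward a higher number. Compound 4 is therefore estimated at 8000 nM, between 1500 nM and 100000 nM.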

Compound 4, half-maximal inhibitory concentration: >= 1000000 nM
Compound 4 ended at the assay's limit; the forecaster's own chance of this, stated with the estimate: 30%; middle value at least 120-fold (2.09 log units) away from the limit.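

Moving the hydroxyl alone, from 4-hydroxyphenyl to 3-hydroxyphenyl, gives in this assay an at least 500-fold higher number from compound 2 to compound 4 (2.70 log units; beyond the scatter), although the two groups have the same heavy atoms and the same counts of donors and acceptors, so at this position the place of the hydroxyl matters, not just its presence. Compound 4 gives >= 1000000 nM, which is a limit of the assay. The steps joining compound 4 to compound 1 and compound 3 run between two limits and cannot be read.

From the compounds shown here alone, whether an amine or a carboxylic acid in place of the hydroxyl would keep a measurable number stays open. Nothing ranks the three compounds other than compound 2 against each other: the limit of >= 1000000 nM in this assay, at which 3 of the 4 values shown sit.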